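Compound 1 to compound 4: a side-chain change

This account rests on a few compounds, and the source may have more. Where it says the series, first, only, none or still open, it means among the compounds named here.

Compound 1 `CCOc1ccccc1-c1ccc(-c2nc3cnccc3c(C[C@H](C)C(=O)O)c2C#N)cc1` gives 2.2
Compound 2 `CC[C@@H](Nc1c(C#N)c(-c2ccc(-c3ccc(OC)cc3)cc2)nc2cnccc12)C(N)=O` gives 2.7
Compound 3 `CC[C@@H](Nc1c(C#N)c(-c2ccc(-c3cccc(Cl)c3)cc2)nc2cnccc12)C(N)=O` gives 3.1

In a physicochemical assay for lipophilicity, read by HPLC, at pH 7.5 (on this read-out higher numbers stand for higher lipophilicity and lower numbers for lower lipophilicity), compound 1 stands lowest of the three, with compound 2 nearest and compound 3 furthest. Compound 4 `CCOc1ccccc1-c1ccc(-c2nc3cnccc3c(N[C@H](CC)C(=O)O)c2C#N)cc1` has not yet been measured. It differs from compound 1 by (1-carboxypropyl)amino in place of 2-carboxypropyl on an aromatic carbon and the swapped group sits opposite the ring nitrogen. Among the compounds with values here, the one measured step is a number 0.40 log units higher from compound 2 to compound 3 (beyond the scatter) and it is modest, but it concerns 3-chlorophenyl in place of 4-methoxyphenyl and not this side chain. Within the data shown here, no measured step covers the change itself, so the expectation rests on compound 1 at 2.2 alone. The expected step is a number 0.10 log units lower from compound 1 to compound 4 (within the scatter) and no shift beyond the scatter is expected. The estimate for compound 4 is 2.1 (expected range 1.6 to 2.6).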

Compound 4, distribution coefficient: 2.1
Beside the measured number, compound 4's estimate shows no gap at the digits printed; the range from low to high includes it.
By their numbers in this assay, from the lowest: compounds 4 and 1 (each within the scatter of the next); then compound 2; then compound 3.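

In this assay, within the data shown here, the change at this position, opposite the ring nitrogen and ortho to a cyano group, reads a number 0.10 log units lower from compound 1 to compound 4 (within the scatter) and gives the first measured step for this side chain. It shows that (1-carboxypropyl)amino can take the place of 2-carboxypropyl on this aromatic carbon, with its added nitrogen, without a shift beyond the scatter. Nothing measured here explains this result. The compounds shown leave open whether a longer chain on that nitrogen, or a tetrazole in place of the carboxylic acid, would also stay within the scatter.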